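Fluorophenyl hydrazides: the step from compound 1 to compound 3

A few compounds are considered here, and "the series" means these few. Any claim that something is new, unique, unknown or untested is made for them only; others in the source may bear on it.

In a functional assay on A549 cells (Homo sapiens) for antiproliferative activity, read by MTT assay, with a stated time of 24 h (a lower number here means a stronger inhibitor, a higher number a weaker inhibitor), compound 1 (`O=C(NNc1ccccc1F)c1ccc(NS(=O)(=O)c2cnc(O)nc2O)cc1`) gives 11700 nM, and compound 2 (`O=C(NNc1ccccc1F)c1cccc(NS(=O)(=O)c2cnc(O)nc2O)c1`) gives 11100 nM. Among the compounds with values here, these two values lie within the scatter of each other, so compound 1 stands level with the only other measured compound.

Compound 3 (`O=C(NNC(=O)c1ccc(NS(=O)(=O)c2cnc(O)nc2O)cc1)c1ccc(F)cc1`) has not yet been measured. Its difference from compound 1 is (4-fluorophenyl)carbonyl in place of 2-fluorophenyl on an amine nitrogen. In words, this places (4-fluorophenyl)carbonyl in place of 2-fluorophenyl on an amine nitrogen, which also reads as (2-fluorophenyl)amino to ((4-fluorophenyl)carbonyl)amino.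

Within the data shown here, no measured pair shows this exchange, so its size cannot be read from the data. Among the measured compounds shown here, the only anchors are compound 1 at 11700 nM and compound 2 at 11100 nM, and the expectation stays close to them, with no firm direction and no step beyond the scatter. The expected change is a 1.2-fold lower number from compound 1 to compound 3 (0.07 log units; within the scatter), and a wide margin on both sides is kept. In this assay the estimated value for compound 3 is 10000 nM, with an expected range of 3500 nM to 30000 nM.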

Compound 3, half-maximal inhibitory concentration: > 20000 nM
Compound 3 was reported as a limit; the forecaster's own chance of this, stated with the estimate: 10%; middle value at least 2.0-fold (0.30 log units) away from the limit.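

In this assay, compound 3 is recorded only as a limit, > 20000 nM, and not as a number. Placing (4-fluorophenyl)carbonyl in place of 2-fluorophenyl on an amine nitrogen gives the first single-place step in the series, an at least 1.7-fold higher number from compound 1 to compound 3 (0.23 log units; that floor lies within the scatter), which is a floor on the change and does not fix its full size. Compounds 1 and 2 gave no view of this position, and the new reading bounds the exchange from one side only, so the series still has no measured size for it: the limit of > 20000 nM in this assay, at which 1 of the 3 values shown sits.

The exchange adds a carbonyl and also changes the fluorophenyl group from 2-fluorophenyl to 4-fluorophenyl, and the compounds shown cannot separate these two parts of the change. From the compounds shown here alone, compounds carrying 4-fluorophenyl or (2-fluorophenyl)carbonyl on the same amine nitrogen of the core of compound 1 would show which part matters, and whether the step extends well past its floor remains open.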